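The compounds below may be only part of what the source reports. "The series", "measured", "known", "first", "only" and "open" are said of these compounds alone.

Measured so far:
- compound 1 `Cc1nc(S(C)(=O)=O)ccc1Oc1ncnc(OC2CCN(C(=O)OC3CCC3)CC2)c1F` gives 81% in a functional assay on isolated protein for inhibition of Glucose-dependent insulinotropic receptor (Rattus norvegicus), read by HTRF and cAMP accumulation; a lower number here means a smaller maximal response, a higher number a larger maximal response
- compound 2 `Cc1nc(S(C)(=O)=O)ccc1Oc1ncnc(OC2CCN(C(=O)OC(C)(C)CF)CC2)c1F` gives 95%
- compound 3 `Cc1nc(S(C)(=O)=O)ccc1Oc1ncnc(OC2CCN(C(=O)OC3COC3)CC2)c1F` gives 66%

Compound 2 stands highest of these three numbers in this assay; compound 1 is nearest, and compound 3 furthest. The step of a number 14 percentage points higher from compound 1 to compound 2 (beyond the scatter) and the step of a number 29 percentage points lower from compound 2 to compound 3 (beyond the scatter) show that the group on the oxygen of the carbonyl shifts the maximal response by a modest amount in either direction, while a number 15 percentage points lower from compound 1 to compound 3 (beyond the scatter) lies between them in size.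

Compound 4 `Cc1nc(S(C)(=O)=O)ccc1Oc1ncnc(OC2CCN(C(=O)C(F)(F)F)CC2)c1F` has not been measured. It differs from compound 2 as follows: a group of 4 heavy atoms (1 carbon, 3 fluorine; no ring) in place of a group of 6 heavy atoms (4 carbon, 1 oxygen, 1 fluorine; no ring), on a carbonyl carbon. Among the measured compounds shown here, no measured step replaces the oxygen-bearing group on the carbonyl by a trifluoromethyl, so the three carbamate steps bear on it only loosely: they set the scale of what a change at this end of the molecule has done so far. The account therefore expects compound 4 to fall within that scale, somewhat below compound 2, with a step of a number 20 percentage points lower from compound 2 to compound 4 (beyond the scatter). The estimate for compound 4 is 75%, with a range from 50% to 95%.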

Compound 4, largest response reached (reported as efficacy), in percent of the reference or control that the assay uses: 76%
Compound 4: the middle estimate sits 1 percentage points below what was measured, within the range that was stated.
By their numbers in this assay, from the lowest: compounds 3, 4 and 1 (each within the scatter of the next, the first and the last beyond it); then compound 2.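

On the carbonyl carbon, trifluoromethyl is the only group shown that is not attached through an oxygen, yet in this assay it does not separate from two of the oxygen-bearing groups: the readings are a number 5 percentage points lower from compound 1 to compound 4 (within the scatter) and a number 10 percentage points higher from compound 3 to compound 4 (within the scatter). Among the compounds shown here, only compound 2 stands apart, with a number 19 percentage points lower from compound 2 to compound 4 (beyond the scatter), so a sizeable maximal response at this position does not depend on an attached oxygen, while the highest value so far goes with the 1-(fluoromethyl)-1-methylethyl group of compound 2. Nothing measured here gives a reason for these steps.

Open, as far as these compounds go, is whether a tert-butyloxy group without its fluorine would keep the response of compound 2. Also open, from the compounds shown here alone, is how a plain methyl, a longer alkyl chain or an amine on this carbonyl would compare with trifluoromethyl.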